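A Nitro Group Added to a Weak Cytotoxic Series

The source may hold more compounds than are shown below. What is called first, only, known or untested is meant among the compounds shown, and "the series" means these compounds.

Of the compounds shown here, three built on one shared core have been tested in a functional assay on MCF7 cells (Homo sapiens) for cytotoxicity, read by MTT assay, with a stated time of 24 h; a higher number here means a weaker inhibitor, a lower number a stronger inhibitor. Compound 1 `O=C(CN1CCN(c2ccccc2Cl)CC1)N1CCN(c2nnc(-c3ccccc3)c(-c3ccccc3)n2)CC1` gives 263000 nM in this assay. Compound 2 `Cc1ccc(-c2nnc(N3CCN(C(=O)CN4CCN(c5ccc(Cl)cc5)CC4)CC3)nc2-c2ccc(C)cc2)cc1` gives 660000 nM in this assay. Compound 3 `COc1ccc(-c2nnc(N3CCN(C(=O)CN4CCN(c5ccccc5)CC4)CC3)nc2-c2ccc(OC)cc2)cc1` gives only a limit in this assay, > 863000 nM. That figure is not a measured potency but the edge of what this assay could resolve, and the limit of > 863000 nM in this assay, at which 1 of the 3 values shown sits, marks where that edge lies. Compound 3 therefore stands at the boundary of the measurable range, while compound 1 and compound 2 sit deep in the weak region as well.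

Compound 4 `COc1ccc(-c2nnc(N3CCN(C(=O)CN4CCN(c5ccc([N+](=O)[O-])cc5)CC4)CC3)nc2-c2ccc(OC)cc2)cc1` differs from compound 3 by one change: nitro in place of hydrogen on an aromatic carbon. Among the compounds with values here, no measured pair shows the effect of this change, so its size can only be judged against the whole set, in which every member is a weak inhibitor. The step from compound 3 to compound 4 is expected to be an at least 1.0-fold lower number from compound 3 to compound 4 (0.03 log units; that floor lies within the scatter), nothing beyond the usual scatter in either direction. Compound 4 is expected to give about 800000 nM in this assay, somewhere between 300000 nM and 2500000 nM, with a real chance that again only a limit is reported.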

Compound 4, half-maximal inhibitory concentration: > 801000 nM
Compound 4 was reported as a limit; the forecaster's own chance of this, stated with the estimate: 50%; middle value at least 1.0-fold (0.00 log units) away from the limit.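

In this assay, compound 3 and compound 4 both give only a limit, not a measured number, and the step between them cannot be read. The compounds shown leave open whether nitro in place of hydrogen on an aromatic carbon changes potency at all, and in which direction.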